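A Chloro-to-Hydrogen Swap in a Growth Inhibition Series

The source may report more compounds than this note shows. Statements on the series, on what has been measured and on what is new or still open speak of the compounds shown alone.

Of the compounds shown here, two have been measured in a functional assay on SK-MEL-5 cells (Homo sapiens) for inhibition; a higher number here means a weaker inhibitor of growth, a lower number a stronger inhibitor of growth. Compound 1 `COc1cc(/C=C/C(=O)c2cccc(-n3cc(-c4ccc(Cl)cc4)[nH]c3=O)c2)cc(OC)c1OC` gives 8700 nM, and compound 2 `COc1cc(/C=C/C(=O)c2cccc(-n3cc(-c4ccccc4)[nH]c3=O)c2)ccc1O` gives 1590 nM. Compound 1 therefore has the highest number of the two; its nearest neighbour, compound 2, sits at a lower number, and the gap between these two lies beyond the usual scatter of this assay. Compound 2 differs from compound 1 in more than one place, so no single change can be read from that pair alone.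

Compound 3 `COc1cc(/C=C/C(=O)c2cccc(-n3cc(-c4ccccc4)[nH]c3=O)c2)cc(OC)c1OC` has not yet been measured. It differs from compound 1 in one place: hydrogen in place of chloro on an aromatic carbon, which one bond further out reads as 4-chlorophenyl to phenyl. Going by the values given here, no measured pair shows this change by itself. Compound 2, which also carries the phenyl, shows the lower number, but its other difference from compound 1 blurs that reading. The step of a 1.9-fold lower number from compound 1 to compound 3 (0.29 log units; within the scatter) is expected to be a modest move toward a lower number, of a size that may or may not clear the scatter. Compound 3 is estimated at 4500 nM, within a range from 1500 nM to 13000 nM.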

Compound 3, concentration for 50% growth inhibition: 1400 nM
Compound 3: middle estimate off by 3.2-fold (0.51 log units), on the high side; measured number outside the range, below it.
By their numbers in this assay, from the lowest: compounds 3 and 2 (each within the scatter of the next); then compound 1.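

In this assay, hydrogen in place of chloro on this aromatic carbon, with the rest of the molecule unchanged, gives a 6.2-fold lower number from compound 1 to compound 3 (0.79 log units; beyond the scatter). Going by these compounds alone, this is the first reading of the change by itself, since the earlier comparison with compound 2 also carried a difference in the other aromatic ring, and it shows that, in this pair, the 4-chlorophenyl compound is the weaker inhibitor of growth and the chloro is not needed for activity on these cells. Nothing shown gives a reason for this step, which stands as an observation on a single pair.

The compounds shown leave open whether the step belongs to chloro specifically or would recur with other groups on the same carbon, such as fluoro, methoxy, an amine or a carboxylic acid. They also leave open whether the same swap gives a step of similar size when the other aromatic ring carries the hydroxy and methoxy groups of compound 2, as no 4-chlorophenyl partner of compound 2 appears among them.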